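A few compounds are considered here, and "the series" means these few. Any claim that something is new, unique, unknown or untested is made for them only; others in the source may bear on it.

Working notes on the series. Within the data shown here, compound 1 `C=C1CCC[C@H]2[C@](C)(CC[C@]3(C)CC[C@@H]([C@@H](C)C(=O)O)OO3)[C@@H](C)CC[C@]12C` gives the lowest of the two numbers so far: in a functional assay on UO-31 cells (Homo sapiens) for inhibition (a lower number here means a stronger inhibitor of growth, a higher number a weaker inhibitor of growth), compound 1 gives 900 nM, while compound 2 `C=C1CCCC(C)(C)C1CC[C@@]1(C)CC[C@H]([C@@H](C)C(=O)O)OO1` in this assay gives 4310 nM, a gap beyond the scatter. Compound 3 `C=C1CCC[C@H]2[C@](C)(CC[C@]3(C)CC[C@H]([C@@H](C)C(=O)O)OO3)[C@@H](C)CC[C@]12C` differs from compound 1 only in configuration: the two compounds have the same atoms and bonds and differ only in configuration as drawn: 1 of 7 stereo elements differ; a stereocentre at a saturated ring carbon is drawn S in compound 1 and R in compound 3. Among the measured compounds shown here, no measured pair isolates such a change, so the size of the step from compound 1 to compound 3 is open; a modest weakening is expected, a 1.7-fold higher number from compound 1 to compound 3 (0.22 log units; within the scatter), though a result within the scatter is also plausible. Compound 3 is therefore estimated at 1500 nM in this assay, within 500 nM to 5000 nM.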

Compound 3, concentration for 50% growth inhibition: 1220 nM
Beside the measured number, compound 3's estimate is 1.2-fold (0.09 log units) above it; the measured number falls inside the stated range.
By their numbers in this assay, from the lowest: compounds 1 and 3 (each within the scatter of the next); then compound 2.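

In this assay, among these compounds, the stereocentre at the saturated ring carbon going from S to R gives a 1.4-fold higher number from compound 1 to compound 3 (0.13 log units; within the scatter); this is the first measured pair to isolate a change of configuration. At this ring carbon, the drawn configuration does not separate the two compounds in this read-out. The reading rests on one point: the fact that compounds 1 and 3 differ only in the configuration as drawn.

On these data alone, it remains open whether this holds when a primary amide stands in place of the carboxylic acid. As far as these compounds go, the other stereocentres of the shared core also remain open.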